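Fluoro to methoxy and cytotoxicity across two related cores

The compounds below may be only part of what the source reports. "The series", "measured", "known", "first", "only" and "open" are said of these compounds alone.

Compound 1 `O=C(CSc1nc(Cc2c(Cl)cccc2Cl)cc(=O)[nH]1)c1ccc(F)cc1`: in an ADME assay on MT4 cells (Homo sapiens) for cytotoxicity, read by MTT assay (on this read-out lower numbers stand for higher toxicity in this test and higher numbers for lower toxicity in this test), compound 1 gives > 59000 nM, which is a limit of the test.
Compound 2 `COc1ccc(C(=O)CSc2nc(Cc3c(Cl)cccc3Cl)cc(=O)[nH]2)cc1`: in this assay compound 2 gives > 11000 nM, also a limit.
Compound 3 `CCc1c(Cc2c(F)cccc2F)nc(SCC(=O)c2ccc(F)cc2)[nH]c1=O`: in this assay compound 3 gives > 60000 nM, again a limit.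

Compound 1 and compound 2 differ only by methoxy in place of fluoro on an aromatic carbon. The step that the two limits leave unreadable from compound 1 to compound 2; both values are limits, as the limit of > 59000 nM in this assay, at which 1 of the 3 values shown sits, and the limit of > 11000 nM in this assay, at which 1 of the 3 values shown sits, show, so its size cannot be read. Compound 3 carries a different core; the difference between the two cores is not broken down here. Compound 4 `CCc1c(Cc2c(F)cccc2F)nc(SCC(=O)c2ccc(OC)cc2)[nH]c1=O` is the untested partner of compound 3, differing by methoxy in place of fluoro on an aromatic carbon, the same change as that between compound 1 and compound 2. Since every measured value sits at a limit, with compound 3 at the limit of > 60000 nM in this assay, at which 1 of the 3 values shown sits, the step expected from the change is a number no higher from compound 3 to compound 4 (the limit leaves the size open), and compound 4 is expected to give about 60000 nM, most likely again reported only as a limit.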

Compound 4, half-maximal cytotoxic concentration: > 58000 nM
Compound 4 was reported as a limit (the forecaster's own chance of this, stated with the estimate: 85%); the middle value lies beyond the limit too.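

Compound 3 and compound 4 are both reported only as limits in this assay, so no step can be read between them. The compounds shown leave open whether methoxy in place of fluoro changes cytotoxicity at all.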